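Ester to amide: an untested step toward compound 4

A few compounds are considered here, and "the series" means these few. Any claim that something is new, unique, unknown or untested is made for them only; others in the source may bear on it.

Compound 1 `COc1ccc(-c2ccc(F)c(C(=O)Nc3c[nH]nc3C(=O)Nc3ccc(F)cc3)c2F)cn1`: "not determined" (no result reported) in a functional assay on A2058 cells (Homo sapiens) for antiproliferative activity, read by luminescence and CellTiter-Glo, with a stated time of 96 h; on this read-out higher numbers stand for weaker inhibition and lower numbers for stronger inhibition.
Compound 2 `NS(=O)(=O)c1ccc(Nc2nc(-c3cccc(-c4ccccc4)c3)c3nc[nH]c3n2)cc1`: > 100000 nM, a limit of the assay rather than a number.
Compound 3 `COC(=O)c1cccc(-c2ccc(F)c(C(=O)Nc3c[nH]nc3C(=O)Nc3ccc(F)cc3)c2F)c1`: "not determined" (no result reported).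

Compound 3 therefore stands without a value of its own. Of the three entries shown, one is a limit, (the limit of > 100000 nM in this assay, at which 1 of the 3 values shown sits), and the other two carry no number at all, so nothing here tells how strongly compound 3 inhibits growth of these cells.

Compound 4 `CN1CCC(CNC(=O)c2cccc(-c3ccc(F)c(C(=O)Nc4c[nH]nc4C(=O)Nc4ccc(F)cc4)c3F)c2)CC1` is still to be measured. It differs from compound 3 in one place: ((1-methylpiperidin-4-yl)methyl)amino in place of methoxy on a carbonyl carbon. For the measured compounds named here, no step between measured compounds exists, so the size and direction of this change cannot be read from the data, and only a broad expectation can be given.

Compound 4 is estimated at 2000 nM, with a likely range from 150 nM to 30000 nM.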

Compound 4, half-maximal inhibitory concentration: 3340 nM
Compound 4: middle estimate off by 1.7-fold (0.22 log units), on the low side; low and high end bracket the measured number.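

For the compounds shown here, compound 3 carries no number, so the change to compound 4, at 3340 nM, gives no step that can be read. Still open, from the compounds shown here alone, is whether ((1-methylpiperidin-4-yl)methyl)amino in place of methoxy strengthens or weakens inhibition.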